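Valine-type Ester Amide Variant Expected Within Scatter

This account rests on a few compounds, and the source may have more. Where it says the series, first, only, none or still open, it means among the compounds named here.

In a functional assay on A549 cells (Homo sapiens) for cytotoxicity, read by MTT assay, with a stated time of 24 h (a higher number here means a weaker inhibitor, a lower number a stronger inhibitor), compound 2 `COC(=O)CCNC(=O)Cn1cc(C2=C(c3c[nH]c4ccccc34)C(=O)N(C)C2=O)c2ccccc21` gives 37600 nM, the larger of the two numbers shown, though compound 1 `COC(=O)[C@H](NC(=O)Cn1cc(C2=C(c3c[nH]c4ccccc34)C(=O)N(C)C2=O)c2ccccc21)[C@@H](C)O` gives 25700 nM and the step of a 1.5-fold higher number from compound 1 to compound 2 (0.17 log units; within the scatter) is within the scatter. Compound 3 `COC(=O)[C@H](NC(=O)Cn1cc(C2=C(c3c[nH]c4ccccc34)C(=O)N(C)C2=O)c2ccccc21)C(C)C` differs from compound 2 in that (1-(methoxycarbonyl)-2-methylpropyl in place of 2-(methoxycarbonyl)ethyl on an amide-type nitrogen). Within the data shown here, the only measured step that bears on this change, another swap of the chain on the same amide-type nitrogen, is a 1.5-fold higher number from compound 1 to compound 2 (0.17 log units; within the scatter), so no step beyond the scatter is expected in this assay in either direction. Compound 3 is therefore estimated at 30000 nM, between 12000 nM and 80000 nM, a step of a 1.3-fold lower number from compound 2 to compound 3 (0.10 log units; within the scatter).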

Compound 3, half-maximal inhibitory concentration: 30600 nM
Compound 3: middle estimate off by 1.0-fold (0.01 log units), on the low side, and the stated range covers the measured number.
By their numbers in this assay, from the lowest: compounds 1, 3 and 2 (each within the scatter of the next).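

In this assay, 1-(methoxycarbonyl)-2-methylpropyl in place of 2-(methoxycarbonyl)ethyl on the amide-type nitrogen, which adds a defined stereocentre, stays within the scatter (a 1.2-fold lower number from compound 2 to compound 3 (0.09 log units; within the scatter)). Isopropyl in place of 1-hydroxyethyl on the saturated chain carbon also stays within the scatter (a 1.2-fold higher number from compound 1 to compound 3 (0.08 log units; within the scatter)), so all three chains on this nitrogen read alike. Nothing measured gives a reason for this. Going by these compounds, whether a carboxylic acid in place of the methyl ester, or an amine on this chain, would move the number beyond the scatter remains open.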